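Swapping Chloro for Bromo on a Related Core

This account rests on a few compounds, and the source may have more. Where it says the series, first, only, none or still open, it means among the compounds named here.

Of the compounds shown here, three have so far been tested in a functional assay on HeLa cells (Homo sapiens) for antiproliferative activity, read by MTT assay, with a stated time of 48 h; on this read-out higher numbers stand for weaker inhibition and lower numbers for stronger inhibition. Compound 1, `Clc1ccccc1CSc1nnc(-c2cnccn2)o1`, gives 23000 nM in this assay. Compound 2, `Brc1ccccc1CSc1nnc(-c2cnccn2)o1`, gives 8890 nM. The two differ in one place only, (bromo in place of chloro on an aromatic carbon), and that change made a step of a 2.6-fold lower number from compound 1 to compound 2 (0.41 log units; beyond the scatter).

Compound 3, `Clc1ccc(CSc2nnc(-c3cnccn3)s2)cc1`, gives 18900 nM in this assay. How the core of compound 3 differs from the core of compound 1 is not broken down here. The values of compound 3 and compound 1 lie within the scatter of each other, so nothing can be said about which is stronger.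

Compound 4, `Brc1ccc(CSc2nnc(-c3cnccn3)s2)cc1`, has not yet been measured. It differs from compound 3 by bromo in place of chloro on an aromatic carbon. Among the measured compounds shown here, this is the same kind of change as the one from compound 1 to compound 2, but not the same: in compound 1 the halogen sits ortho to a large group, whereas in compound 3 it sits para to a large group, and the two cores also differ. For the measured compounds named here, the only measured example of this kind of change is the single step between compound 1 and compound 2, so the expectation rests on that alone and on the value of compound 3. The step expected in this assay is a 2.0-fold lower number from compound 3 to compound 4 (0.30 log units; within the scatter), judged a little more cautious than the measured one given the different place and core. For compound 4 the estimate in this assay is 9500 nM, with a likely range from 4500 nM to 20000 nM.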

Compound 4, half-maximal inhibitory concentration: 12400 nM
For compound 4 the middle estimate is 1.3-fold (0.12 log units) below the measured one; low and high end bracket the measured number.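

Setting bromo in place of chloro on the aromatic ring of compound 3 gives a 1.5-fold lower number from compound 3 to compound 4 (0.18 log units; within the scatter) in this assay, so this step taken alone cannot be told apart from the ordinary spread of repeated measurements. Placed beside the earlier step on the other core, it gives no sign that the change behaves differently on the two cores: the same change on two cores in this assay, a 2.6-fold lower number (0.41 log units; beyond the scatter) from compound 1 to compound 2 and a 1.5-fold lower number (0.18 log units; within the scatter) from compound 3 to compound 4, 1.7-fold (0.23 log units) apart, within the scatter of two such steps

Among the compounds shown here, this agreement is compatible with the change carrying over from one core to the other, but it does not show that the step keeps the same size, or that bromo gives stronger inhibition on every core, as only one of just two steps lies beyond the scatter and the halogen also sits in a different place in the two pairs.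

The compounds shown leave open how the core and the place of the halogen each contribute, as no pair here varies the place of the halogen on an unchanged core. They also leave open whether other groups at the same position, such as fluoro, methoxy, an amine or a carboxylic acid, would fit alongside chloro and bromo.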